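Swapping the Pyridine Nitrogen Position on the Sulfonamide

This account rests on a few compounds, and the source may have more. Where it says the series, first, only, none or still open, it means among the compounds named here.

Three compounds have been measured in a functional assay on CHO-K1 cells for antagonist activity at prostaglandin E2 receptor EP1 subtype (Homo sapiens), read by FLIPR and calcium flux; on this read-out lower numbers stand for stronger inhibition and higher numbers for weaker inhibition:

Compound 1, `CCc1ccccc1N(CC(=O)NCc1ccccc1)S(=O)(=O)c1ccc(C)cc1`: compound 1 gives 224 nM.
Compound 2, `CCc1ccccc1N(CC(=O)NCc1ccc(Cl)cc1)S(=O)(=O)c1ccc(C)cc1`: compound 2 gives 11.5 nM.
Compound 3, `Cc1ccc(S(=O)(=O)N(CC(=O)NCc2ccc(Cl)cc2)c2cccnc2)cc1`: compound 3 gives < 1450 nM, a limit of the assay and not a number, as described by the limit of < 1450 nM in this assay, at which 1 of the 3 values shown sits.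

Compound 3 therefore stands nowhere definite among the numbers shown; only a limit is known for it. Compound 4, `Cc1ccc(S(=O)(=O)N(CC(=O)NCc2ccc(Cl)cc2)c2ccccn2)cc1`, has not been measured; it differs from compound 3 by pyridin-2-yl in place of pyridin-3-yl on a sulfonamide nitrogen.

Two measured steps exist. The step of a 19-fold lower number from compound 1 to compound 2 (1.29 log units; beyond the scatter) concerns another place in the molecule and another kind of change. The step that the limit leaves unreadable from compound 2 to compound 3 touches the same sulfonamide nitrogen, but its size cannot be read. Neither tells how moving the ring nitrogen within the pyridine changes this assay, so no direction beyond the scatter can be drawn from them.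

Compound 4 is expected to give about 1200 nM, in the range 150 nM to 10000 nM. The step this estimate means, a step that the limit leaves unreadable from compound 3 to compound 4, is expected to be small, with a fair chance that only a limit is reported again.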

Compound 4, inhibition constant: < 1450 nM
Compound 4: no number, only a limit; the forecaster's own chance of this, stated with the estimate: 40%; the middle value lies beyond the limit too.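

In this assay compound 4 gives < 1450 nM, a limit of the assay and not a number. Compound 3 also has only a limit, so the steps from compound 3 to compound 4 and from compound 2 to compound 4 cannot be read. As far as these compounds go, it remains open whether pyridin-2-yl in place of pyridin-3-yl changes inhibition at all.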